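Swapping the aryl amine substituent on a pyrrolinone core

The source may report more compounds than this note shows. Statements on the series, on what has been measured and on what is new or still open speak of the compounds shown alone.

Of the compounds shown here, two have been measured in a functional assay on SAOS-2 cells (Homo sapiens) for antiproliferative activity, read by MTT assay, with a stated time of 72 h; a higher number here means a weaker inhibitor, a lower number a stronger inhibitor. Compound 1 `CC(C)OC1=C(C(=O)c2ccccc2)C(c2ccc(Br)cc2)N(CCCn2ccnc2)C1=O` gives 23000 nM. Among the measured compounds shown here, compound 2 `O=C(C1=C(Nc2cccc(Br)c2)C(=O)N(CCCn2ccnc2)C1c1ccc(Br)cc1)c1ccccc1` gives 9090 nM, the lower of the two numbers; the step of a 2.5-fold lower number from compound 1 to compound 2 (0.40 log units; beyond the scatter) is the only measured step so far. Compound 3 `O=C(C1=C(NCc2ccccc2)C(=O)N(CCCn2ccnc2)C1c1ccc(Br)cc1)c1ccccc1` has not yet been measured. It differs from compound 2 by benzyl in place of 3-bromophenyl on an amine nitrogen. For the measured compounds named here, no measured step touches the group on this amine nitrogen: the single step, from isopropoxy to (3-bromophenyl)amino, concerns the whole substituent on the double-bonded ring carbon and says nothing about exchanging one aryl for a benzyl within the amine. Without a direct precedent, a step of at most modest size in this assay, in either direction or none beyond the scatter, is expected, as a 1.1-fold higher number from compound 2 to compound 3 (0.04 log units; within the scatter). Compound 3 is therefore estimated at 10000 nM, within a range from 4000 nM to 25000 nM.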

Compound 3, half-maximal inhibitory concentration: 31600 nM
Compound 3: middle estimate off by 3.2-fold (0.50 log units), on the low side; measured number above the stated range.
By their numbers in this assay, from the lowest: compound 2; then compounds 1 and 3 (each within the scatter of the next).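

In this assay the group on the amine nitrogen turns out to matter: exchanging 3-bromophenyl for benzyl gives a 3.5-fold higher number from compound 2 to compound 3 (0.54 log units; beyond the scatter) even though both groups have the same count of heavy atoms. Benzylamino on the double-bonded ring carbon does not separate from isopropoxy, with a 1.4-fold higher number from compound 1 to compound 3 (0.14 log units; within the scatter), so among these compounds an amine at this place is not enough and only the (3-bromophenyl)amino of compound 2 stands apart. Nothing available explains the difference between the two groups.

The compounds shown leave open whether the change follows the loss of the bromine or the methylene of benzyl; this step alters both at once. A plain phenyl or a 3-bromobenzyl on this amine nitrogen would separate the two.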